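Pyrrolidine amides on the shared core: fluoro to methoxy

The source may hold more compounds than are shown below. What is called first, only, known or untested is meant among the compounds shown, and "the series" means these compounds.

Compound 3 `O=C(NCCCN1CCCC1)c1cc(-c2ccccc2F)nc2[nH]ncc12` gives the highest of the three numbers measured in an assay on isolated protein for inhibition of N-lysine methyltransferase SMYD2 (Homo sapiens) (on this read-out lower numbers stand for stronger inhibition and higher numbers for weaker inhibition), at 16800 nM. Compound 1 `Cc1ccccc1-c1cc(C(=O)NCC(O)CN2CCCC2)c2cn[nH]c2n1` gives 12100 nM in this assay, a gap from compound 3 that lies within the scatter. For the measured compounds named here, compound 2 `O=C(NCCCN1CCCC1)c1cc(-c2ccccc2Cl)nc2[nH]ncc12` gives 8000 nM, and the one-place step a 2.1-fold higher number from compound 2 to compound 3 (0.32 log units; beyond the scatter) is the only measured step.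

Compound 4 `COc1ccccc1-c1cc(C(=O)NCCCN2CCCC2)c2cn[nH]c2n1` differs from compound 3 by methoxy in place of fluoro on an aromatic carbon. Going by the values given here, no measured step swaps fluoro for methoxy, and compound 1 carries its methyl on a different amide chain, so no single-change comparison to it exists. Among the compounds with values here, the only step that bears on a change at this aromatic carbon is the modest one from compound 2 to compound 3, where the larger group gave the lower number. Methoxy is likewise larger than fluoro, so a step of similar size toward a lower number is expected, though a result within the scatter cannot be excluded.

Compound 4 is therefore estimated at 10000 nM in this assay, with a range of 4000 nM to 30000 nM, which corresponds to the expected step of a 1.7-fold lower number from compound 3 to compound 4 (0.23 log units; within the scatter).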

Compound 4, half-maximal inhibitory concentration: 14500 nM
Estimate against measurement, compound 4: 1.5-fold (0.16 log units) below; low and high end bracket the measured number.
By their numbers in this assay, from the lowest: compounds 2, 1, 4 and 3 (each within the scatter of the next, the first and the last beyond it).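

Methoxy in place of fluoro at this aromatic carbon, ortho to a large group, gives a 1.2-fold lower number from compound 3 to compound 4 (0.06 log units; within the scatter) in this assay and so does not separate the two compounds, and the swap of chloro for methoxy gives a 1.8-fold higher number from compound 2 to compound 4 (0.26 log units; within the scatter) and does not separate those two either. Only chloro and fluoro stand apart here, by a 2.1-fold higher number from compound 2 to compound 3 (0.32 log units; beyond the scatter) and with compound 4 falling within the scatter of both, so going from the 1 heavy atom of fluoro to the 2 of methoxy, with 1 hydrogen-bond acceptor added, brings no readable step. No supporting evidence bears on why these readings fall as they do.

On these data alone, whether an amine, a hydroxyl or a carboxylic acid at this carbon would move the number beyond the scatter remains open. Compound 1 differs from the others in more than one place, so the effect of its hydroxyl-bearing chain cannot be read apart from its methyl.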